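One Inverted Stereocentre in a Growth-Inhibition Series

A few compounds are considered here, and "the series" means these few. Any claim that something is new, unique, unknown or untested is made for them only; others in the source may bear on it.

Measured so far in a functional assay on DLD-1 cells (Homo sapiens) for inhibition, read by luminescence, with a stated time of 3 days; on this read-out higher numbers stand for weaker inhibition of growth and lower numbers for stronger inhibition of growth:
- compound 1 `CC[C@@H]1CC[C@@H](C(=O)N2CCN(C)CC2)N1C(=O)C1=C(C(C)C)N2C(=N[C@@](C)(c3ccc(Cl)cc3)[C@H]2c2ccc(Cl)cc2)S1`: 4000 nM
- compound 2 `CC[C@@H]1CC[C@@H](C(=O)N2CCN(C(C)=O)[C@H](C)C2)N1C(=O)C1=C(C(C)C)N2C(=N[C@@](C)(c3ccc(Cl)cc3)[C@H]2c2ccc(Cl)cc2)S1`: 10000 nM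

Of the two measured compounds, compound 2 carries the higher number, so it shows the weaker inhibition of growth in this assay. The next compound, compound 3 `CC[C@@H]1CC[C@@H](C(=O)N2CCN(C(C)=O)[C@@H](C)C2)N1C(=O)C1=C(C(C)C)N2C(=N[C@@](C)(c3ccc(Cl)cc3)[C@H]2c2ccc(Cl)cc2)S1`, departs from it in one way only: the two compounds have the same atoms and bonds and differ only in configuration as drawn: 1 of 5 stereo elements differ; a stereocentre at a saturated ring carbon is drawn R in compound 2 and S in compound 3. No atoms leave or enter, and a stereocentre at a saturated ring carbon is drawn R in compound 2 and S in compound 3.

Within the data shown here, only one measured step bears on this change, a 2.5-fold higher number from compound 1 to compound 2 (0.40 log units; beyond the scatter). That modest step replaced a whole group and did not alter configuration alone, so it offers only a rough guide to how far the numbers may move. Among the measured compounds shown here, no measured pair isolates a change of this kind, and the data give no direction for it. A change no larger than the scatter is therefore expected. The estimated step is a 1.3-fold lower number from compound 2 to compound 3 (0.10 log units; within the scatter). For compound 3 the expected value is 8000 nM, with an estimated range from 3000 nM to 20000 nM.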

Compound 3, concentration for 50% growth inhibition in the DLD-1 assay: 2600 nM
Estimate against measurement, compound 3: 3.1-fold (0.49 log units) above; the whole stated range lies above it.
By their numbers in the DLD-1 assay, from the lowest: compounds 3 and 1 (each within the scatter of the next); then compound 2.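

In the DLD-1 assay, compound 2 gives 10000 nM and compound 3 gives 2600 nM, and the single inversion gives a 3.8-fold lower number from compound 2 to compound 3 (0.59 log units; beyond the scatter), so the configuration at this saturated ring carbon moves the number beyond the scatter, something the earlier step could not show, as it replaced a whole group; the step can be tied to this stereocentre alone because of one fact: the fact that compounds 2 and 3 differ only in the configuration as drawn. In the DLD-1 assay, the S form also changes the picture for the larger group on the carbonyl carbon, with a 1.5-fold lower number from compound 1 to compound 3 (0.19 log units; within the scatter), so the replacement that gave a 2.5-fold higher number from compound 1 to compound 2 (0.40 log units; beyond the scatter) with the R form leaves no difference beyond the scatter with the S form. In a physicochemical assay for solubility, read by HPLC, in phosphate buffer, at pH 6.8 (on this read-out higher numbers stand for higher solubility and lower numbers for lower solubility), compound 2 gives 25 ug/mL and compound 3 gives 24 ug/mL, and the same inversion gives a 1.0-fold lower number from compound 2 to compound 3 (0.02 log units; within the scatter), so the two forms separate in growth inhibition but not on this solubility read-out.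

The compounds shown leave open whether the same inversion would matter as much if an ethyl or a hydroxymethyl group stood in place of the methyl group on this stereocentre. They also leave open whether the gap between the two forms would persist with a different group, such as a sulfonyl group, in place of the acetyl group on the ring.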